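The source may report more compounds than this note shows. Statements on the series, on what has been measured and on what is new or still open speak of the compounds shown alone.

Of the compounds shown here, three sharing one core have been tested in a functional assay on SK-BR-3 cells (Homo sapiens) for cytotoxicity, read by MTT assay, with a stated time of 72 h; a lower number here means that less compound is needed, a higher number that more compound is needed for the effect. Among the measured compounds shown here, compound 1 `CCc1cccc2c(OC)c(-c3occ(C)c3C(=O)OC)ccc12` is the only one to give a number: in this assay compound 1 gives 1.2 ug/mL. Compound 2 `CCCOC(=O)c1c(C)coc1-c1ccc2c(CC)cccc2c1OC` carries ethyl in place of hydrogen on a saturated chain carbon bound to an oxygen next to a carbonyl group, and in this assay compound 2 reaches only a limit of > 10 ug/mL. Compound 3 `CCc1cccc2c(OC)c(-c3occ(C)c3C(=O)NC)ccc12` carries methylamino in place of methoxy on a carbonyl carbon and likewise stops at a limit: in this assay compound 3 gives > 10 ug/mL. The two measured steps are an at least 8.3-fold higher number from compound 1 to compound 2 (0.92 log units; beyond the scatter) and an at least 8.3-fold higher number from compound 1 to compound 3 (0.92 log units; beyond the scatter), while the step between the two limits, a step that the two limits leave unreadable from compound 2 to compound 3, cannot be read. Compound 3 thus stands at the limit of > 10 ug/mL in this assay, at which 2 of the 3 values shown sit, and its true value is not known.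

Compound 4 `CCc1cccc2c(OC)c(-c3occ(C)c3CO)ccc12` changes compound 3 by hydroxymethyl in place of methylcarbamoyl on an aromatic carbon. For the measured compounds named here, no measured step exchanges methylcarbamoyl for hydroxymethyl; the two steps from compound 1 show only that both departures from the methyl ester cost at least a modest step in this assay, and the step from compound 3 starts at a limit. Compound 4 is therefore expected to stay weak, with a step of a number no higher from compound 3 to compound 4 (the limit leaves the size open) that cannot be read against a limit. Compound 4 is accordingly estimated at 10 ug/mL, between 3 ug/mL and 30 ug/mL.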

Compound 4, concentration for half-maximal effect: 0.73 ug/mL
Beside the measured number, compound 4's estimate is 14-fold (1.14 log units) above it, outside the stated range (below it).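

The result shows that this aromatic carbon of the five-membered ring does not need the methoxycarbonyl group for activity in this assay: hydroxymethyl, which has no carbonyl, gives a 1.6-fold lower number from compound 1 to compound 4 (0.22 log units; within the scatter). The earlier compounds shown here showed only departures from the methyl ester that cost activity, whereas the same hydroxymethyl group now stands well clear of both, with an at least 13-fold lower number from compound 3 to compound 4 (1.13 log units; beyond the scatter) and an at least 13-fold lower number from compound 2 to compound 4 (1.13 log units; beyond the scatter). Leaving the methoxycarbonyl group therefore carries no general penalty at this position; the loss belongs to the methylcarbamoyl and propoxycarbonyl groups in particular, and not to every replacement of the ester.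

What an ethoxycarbonyl group, a carboxylic acid or an aminomethyl group would give on this carbon stays open, so the compounds shown do not fix where along such changes activity is kept or lost. The full size of the steps from compound 2 and compound 3 also stays open, as the values of both compounds are limits and not numbers: the limit of > 10 ug/mL in this assay, at which 2 of the 4 values shown sit.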